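The source may hold more compounds than are shown below. What is called first, only, known or untested is meant among the compounds shown, and "the series" means these compounds.

Measured compounds:
compound 2, `COc1ccc2nc(C)cc(OCC(=O)NCc3cc(C)cc(C)c3)c2c1`: 92000 nM
compound 1, `COc1ccc2nc(C)cc(OC(C)(C)C(=O)Nc3cc(C)cc(C)c3)c2c1`: 20000 nM

In a physicochemical assay for solubility, in phosphate buffer, measured as kinetic solubility, with a stated time of 1 h, at pH 7.4 (on this read-out lower numbers stand for lower solubility and higher numbers for higher solubility), compound 2 gives 92000 nM and stands highest of the two numbers measured, with compound 1 nearest at 20000 nM, a gap beyond the usual scatter. Compound 3, `COc1ccc2nc(C)cc(OCC(=O)Nc3c(C)cncc3C)c2c1`, has not been measured. It differs from compound 2 in one place: 3,5-dimethylpyridin-4-yl in place of 3,5-dimethylbenzyl on an amide-type nitrogen. Among the compounds with values here, no pair of measured compounds shows this change, so the step has no precedent here. Compound 3 is estimated at 150000 nM, within 50000 nM to 400000 nM, which would mean an expected step of a 1.6-fold higher number from compound 2 to compound 3 (0.21 log units; within the scatter).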

Compound 3, solubility: 12000 nM
Estimate against measurement, compound 3: 13-fold (1.10 log units) above; measured number outside the range, below it.
By their numbers in this assay, from the lowest: compounds 3 and 1 (each within the scatter of the next); then compound 2.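

In this assay the exchange of 3,5-dimethylbenzyl for 3,5-dimethylpyridin-4-yl on the amide-type nitrogen brings a 7.7-fold lower number from compound 2 to compound 3 (0.88 log units; beyond the scatter) and shows that this position is sensitive to the group it carries. The entering group has 1 hydrogen-bond acceptor where the leaving group has 0, yet the number falls in this pair. Nothing here explains the drop.

As far as these compounds go, the step changes the ring and removes the benzyl carbon together, so the share of each stays open. A 3,5-dimethylpyridin-4-ylmethyl group on the same nitrogen would separate the two.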